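Pyrrolidinyl for piperidinyl on a shared bridged core

A few compounds are considered here, and "the series" means these few. Any claim that something is new, unique, unknown or untested is made for them only; others in the source may bear on it.

Among the compounds with values here, compound 2 `CCN(CC)CC(=O)OC1CC2(N3CCCCC3)CC(c3ccccc3)C1C(c1ccccc1)C2` is one of two compounds measured in an ADME assay on L6 cells (Rattus norvegicus) for cytotoxicity, read by resazurin assay, with a stated time of 72 h (a lower number here means a stronger inhibitor, a higher number a weaker inhibitor), where compound 2 gives 23900 nM. Its companion compound 1 `O=C(CN1CCCCC1)OC1CC2(N3CCCC3)CC(c3ccccc3)C1C(c1ccccc1)C2` gives 14200 nM in this assay, and the two values lie within the usual scatter of each other. Compound 3 `CCN(CC)CC(=O)OC1CC2(N3CCCC3)CC(c3ccccc3)C1C(c1ccccc1)C2` is not yet measured; it differs from compound 2 by pyrrolidin-1-yl in place of piperidin-1-yl on a saturated ring carbon. Within the data shown here, no step between measured compounds shows this change, so compound 3 is expected to stay close to compound 2, with a step of a 1.3-fold lower number from compound 2 to compound 3 (0.10 log units; within the scatter) that is estimated to remain within the scatter. The estimate for compound 3 in this assay is therefore 19000 nM, expected between 8000 nM and 45000 nM.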

Compound 3, half-maximal inhibitory concentration: 49000 nM
Estimate against measurement, compound 3: 2.6-fold (0.41 log units) below; measured number outside the range, above it.
By their numbers in this assay, from the lowest: compounds 1 and 2 (each within the scatter of the next); then compound 3.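

On the saturated ring carbon, pyrrolidin-1-yl in place of piperidin-1-yl is not neutral in this assay: it gives a 2.1-fold higher number from compound 2 to compound 3 (0.31 log units; beyond the scatter) with the diethylamino ester held constant. With pyrrolidin-1-yl held on that carbon, diethylamino in place of piperidin-1-yl on the saturated chain carbon gives a 3.5-fold higher number from compound 1 to compound 3 (0.54 log units; beyond the scatter) and so also shifts the number. Nothing measured here accounts for either step.

From the compounds shown here alone, it remains open whether morpholin-4-yl or dimethylamino on the ring carbon would lie nearer compound 2 or compound 3. Going by these compounds, whether the ring change gives a similar step with piperidin-1-yl on the chain carbon also remains open.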